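The source may report more compounds than this note shows. Statements on the series, on what has been measured and on what is new or still open speak of the compounds shown alone.

Measured compounds in an assay on HEK293 cells for inhibition of kynurenine 3-monooxygenase (Homo sapiens), read by LC-MS, with a stated time of 20 h; on this read-out lower numbers stand for stronger inhibition and higher numbers for weaker inhibition:
compound 1 `O=C(O)CCn1c(=O)oc2cc(OCc3ccccc3)c(Cl)cc21` gives 1580 nM
compound 2 `CC(C)Cc1cc2oc(=O)n(CCC(=O)O)c2cc1Cl` gives 794 nM
compound 3 `C[C@@H](Oc1cc2oc(=O)n(CCC(=O)O)c2cc1Cl)c1ccc(Cl)cn1` gives 100 nM

Compound 3 gives the lowest number of the three; the values of compound 2 and compound 1 both lie clearly above it. Compound 4 `CCOc1cc2oc(=O)n(CCC(=O)O)c2cc1Cl` differs from compound 3 by hydrogen in place of 5-chloropyridin-2-yl on a saturated chain carbon bound to an oxygen on an aromatic ring and a saturated chain carbon. Within the data shown here, the only measured step, a 2.0-fold lower number from compound 1 to compound 2 (0.30 log units; within the scatter), swaps a group on an aromatic carbon, not on this chain carbon, so no measured step bears directly on the change. Compound 1 and compound 3 both carry an aromatic ring on the side chain yet give quite different numbers, so the weight of that ring is uncertain. Removing it is expected to raise the number; the expected step is a 15-fold higher number from compound 3 to compound 4 (1.18 log units; beyond the scatter). Compound 4 is estimated at 1500 nM, within 400 nM to 6000 nM.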

Compound 4, half-maximal inhibitory concentration in the kynurenine 3-monooxygenase assay: 398 nM
Compound 4: middle estimate off by 3.8-fold (0.58 log units), on the high side; measured number below the stated range.
By their numbers in the kynurenine 3-monooxygenase assay, from the lowest: compound 3; then compounds 4, 2 and 1 (each within the scatter of the next, the first and the last beyond it).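

In the kynurenine 3-monooxygenase assay this chain carbon clearly responds to what it carries: losing the 5-chloropyridin-2-yl group gives a 4.0-fold higher number from compound 3 to compound 4 (0.60 log units; beyond the scatter) and methyl in place of phenyl gives a 4.0-fold lower number from compound 1 to compound 4 (0.60 log units; beyond the scatter), so these two aromatic rings do not pull the same way. Ethoxy in place of isobutyl on the aromatic carbon gives a 2.0-fold lower number from compound 2 to compound 4 (0.30 log units; within the scatter) and so separates nothing. In a physicochemical assay for permeability, using PAMPA (on this read-out higher numbers stand for higher permeability and lower numbers for lower permeability), compound 3 gives 60 nm/s. In the physicochemical assay compound 4 gives < 10 nm/s, which is a limit of the assay and not a number. In the physicochemical assay losing the 5-chloropyridin-2-yl group gives an at least 6.0-fold lower number from compound 3 to compound 4 (0.77 log units; beyond the scatter), a step that rests on a limit of the assay for compound 4 and not on a number: the limit of < 10 nm/s in the physicochemical assay, at which 1 of the 2 values shown sits.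

Going by these compounds, whether the chlorine or the ring nitrogen of the 5-chloropyridin-2-yl group carries the step stays open. So does how an amine or a longer chain on this chain carbon would fare.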